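The source may report more compounds than this note shows. Statements on the series, on what has been measured and on what is new or still open speak of the compounds shown alone.

Measured so far in an ADME assay on CHO-K1 cells (Cricetulus griseus) for cytotoxicity, read by MTT assay, with a stated time of 24 h; a lower number here means a stronger inhibitor, a higher number a weaker inhibitor:
compound 1 `O=[N+]([O-])c1cc(-c2nnn(Cc3ccc(Cl)cc3)n2)cc([N+](=O)[O-])c1` gives 170000 nM
compound 2 `O=[N+]([O-])c1cc(-c2nnn(Cc3cccc(Cl)c3)n2)cc([N+](=O)[O-])c1` gives 27000 nM

Among the measured compounds shown here, compound 2 stands at the lowest of the two numbers; the one step that has been measured, a 6.3-fold lower number from compound 1 to compound 2 (0.80 log units; beyond the scatter), is what separates it from compound 1. Compound 3 `COc1ccc(Cn2nnc(-c3cc([N+](=O)[O-])cc([N+](=O)[O-])c3)n2)cc1` carries a different change: 4-methoxyphenyl in place of 3-chlorophenyl on a saturated chain carbon bound to an aromatic nitrogen. The step from compound 1 to compound 2 bears on it only in part, since it shows that exchanging one chlorophenyl for another on this saturated chain carbon already moves this assay by a modest, beyond-scatter amount, a 6.3-fold lower number from compound 1 to compound 2 (0.80 log units; beyond the scatter). Nothing measured here involves a methoxy group, so the direction is uncertain; a higher number than that of compound 2 is expected, of a size near the one seen, a 2.2-fold higher number from compound 2 to compound 3 (0.35 log units; beyond the scatter). Compound 3 is therefore estimated at 60000 nM, within a range from 15000 nM to 250000 nM.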

Compound 3, half-maximal inhibitory concentration: 96000 nM
The estimate for compound 3 lay 1.6-fold (0.20 log units) below the measured number, within the range that was stated.
By their numbers in this assay, from the lowest: compound 2; then compounds 3 and 1 (each within the scatter of the next).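

In this assay, replacing the chloro of the 4-chlorophenyl with methoxy gives a 1.8-fold lower number from compound 1 to compound 3 (0.25 log units; within the scatter), so this change at the same ring position does not separate the two compounds. By contrast, 4-methoxyphenyl in place of 3-chlorophenyl on the saturated chain carbon bound to an aromatic nitrogen gives a 3.6-fold higher number from compound 2 to compound 3 (0.55 log units; beyond the scatter), leaving compound 2, with its 3-chlorophenyl, apart from both 4-substituted compounds among these three. No measurement shown explains why these numbers differ.

The compounds shown leave open whether a 3-methoxyphenyl would read like compound 2, which would tie the lower number to the 3-position rather than to chloro itself. They also leave open how an unsubstituted phenyl, an amine on the ring or a longer chain to the ring would read.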